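The source may hold more compounds than are shown below. What is called first, only, known or untested is meant among the compounds shown, and "the series" means these compounds.

Compound 1 `CC1CCN(C2CCN(S(=O)(=O)c3cccnc3Cl)CC2)CC1` — in an ADME assay on HCT-116 cells (Homo sapiens) for cytotoxicity, read by CellTiter-Glo, with a stated time of 72 h (on this read-out higher numbers stand for weaker inhibition and lower numbers for stronger inhibition), compound 1 gives > 10000 nM, which is a limit of the assay and not a number.
Compound 2 `Cc1ccc(S(=O)(=O)N2CCC(N3CCC(C)CC3)CC2)cc1C` — in this assay compound 2 gives > 5000 nM, again a limit.
Compound 3 `COc1cccc(S(=O)(=O)N2CCC(N3CCC(C)CC3)CC2)c1` — in this assay compound 3 gives > 5000 nM, also a limit.

Compound 3 therefore stands only at a limit, and the two other values shown are limits as well: one sits at the limit of > 10000 nM in this assay, at which 1 of the 3 values shown sits, and two sit at the limit of > 5000 nM in this assay, at which 2 of the 3 values shown sit. Among the compounds with values here, no compound in the set has a read number, so none can be ranked against another.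

The three measured steps are all unreadable for the same reason: a step that the two limits leave unreadable from compound 1 to compound 2, a step that the two limits leave unreadable from compound 1 to compound 3 and a step that the two limits leave unreadable from compound 2 to compound 3. Each changes the aryl group on the sulfonyl sulfur, yet no size comes out of the pair of limits.

Compound 4 `CC1CCN(C2CCN(S(=O)(=O)c3cc(Cl)cc(Cl)c3)CC2)CC1` differs from compound 3 by 3,5-dichlorophenyl in place of 3-methoxyphenyl on a sulfonyl sulfur. The change is of the same kind as the three unreadable steps, an exchange of the aryl group on a sulfonyl sulfur, and every such exchange so far left the value at a limit. Within the data shown here, no measured step bears on the change with a readable size, so no direction can be read from the data. The expectation for compound 4 in this assay is a further limit rather than a number, meaning an expected step that the limit leaves unreadable from compound 3 to compound 4. Compound 4 is estimated at 15000 nM, within a range of 5000 nM to 50000 nM.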

Compound 4, half-maximal inhibitory concentration: > 5000 nM
Compound 4: only a limit was reported; the forecaster's own chance of this, stated with the estimate: 85%; the middle value lies beyond the limit too.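

In this assay compound 4 gives > 5000 nM, a limit and not a number. The steps to compound 4 from compound 1, compound 2 and compound 3 cannot be read. The compounds shown leave open where the value of any of the four lies and whether exchanging the aryl group on the sulfonyl sulfur changes it at all.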